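Shorter chain, new ring amine: what to expect

The source may hold more compounds than are shown below. What is called first, only, known or untested is meant among the compounds shown, and "the series" means these compounds.

Among the measured compounds shown here, in a functional assay on A-375 cells (Homo sapiens) for cytotoxicity, read by MTT assay, with a stated time of 72 h (a lower number here means a stronger inhibitor, a higher number a weaker inhibitor), compound 1 `CN1CCN(CCCCn2c3c(c4ccccc42)C(=O)c2c[n+]([O-])c4ccccc4c2C3=O)CC1` gives 30 nM while compound 2 `CN1CCN(CCCn2c3c(c4ccccc42)C(=O)c2c[n+]([O-])c4ccccc4c2C3=O)CC1` gives 470 nM as the higher of the only two numbers so far. Compound 2 is therefore the weaker inhibitor of this pair.

Compound 3 `O=C1c2c[n+]([O-])c3ccccc3c2C(=O)c2c1c1ccccc1n2CCN1CCCCC1` is still unmeasured. Its difference from compound 2 is piperidin-1-yl in place of (4-methylpiperazin-1-yl)methyl on a saturated chain carbon, two bonds along the chain from an aromatic nitrogen and this turns 3-(4-methylpiperazin-1-yl)propyl into 2-(piperidin-1-yl)ethyl on the aromatic nitrogen. The chain gets shorter and the ring changes in the same move.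

For the measured compounds named here, only one measured step bears on this. The step of a 16-fold higher number from compound 1 to compound 2 (1.19 log units; beyond the scatter) is large, and it also shortened the chain. Going by the values given here, no measured compound carries piperidin-1-yl, so the effect of the new ring is unknown, and a single step does not make a trend. A further rise in the number is therefore expected, though a smaller one held with wide uncertainty. The expected step is a 2.1-fold higher number from compound 2 to compound 3 (0.33 log units; beyond the scatter) in this estimate. For compound 3 the estimated value is 1000 nM with an expected range from 200 nM to 5000 nM in this assay (an estimate only).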

Compound 3, half-maximal inhibitory concentration: 180 nM
For compound 3 the middle estimate is 5.6-fold (0.74 log units) above the measured one, outside the stated range (below it).
By their numbers in this assay, from the lowest: compound 1; then compound 3; then compound 2.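

In this assay, the shorter chain does not bring a further rise in the number once the ring also changes: replacing 3-(4-methylpiperazin-1-yl)propyl with 2-(piperidin-1-yl)ethyl on the aromatic nitrogen gives a 2.6-fold lower number from compound 2 to compound 3 (0.42 log units; beyond the scatter). Shortening the chain therefore does not always go with a weaker compound, and compound 3 is the one that goes against the direction suggested by the first pair, although its chain and ring changed in a single move. Even so, the comparison with the first compound still shows a 6.0-fold higher number from compound 1 to compound 3 (0.78 log units; beyond the scatter), so compound 1 keeps the lowest number of the three, and nothing available here explains these shifts.

Still open, on these data alone, is how much of the drop belongs to the ring and how much to the chain, which a 3-(piperidin-1-yl)propyl or a 2-(4-methylpiperazin-1-yl)ethyl group on the same nitrogen would separate. Also open, as far as these compounds go, is how a longer chain ending in piperidin-1-yl, or the same chains ending in morpholine or an open-chain dimethylamine, would compare with compound 1.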